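Swapping bromo for chloro on a nucleotide core

A few compounds are considered here, and "the series" means these few. Any claim that something is new, unique, unknown or untested is made for them only; others in the source may bear on it.

Compound 1 `O=c1[nH]c(=O)n([C@H]2C[C@@H]3O[PH](O)(O)OC[C@H]3O2)cc1F`: 0.164 ug/mL
Compound 2 `O=c1[nH]c(=O)n([C@H]2C[C@H](O)[C@@H](COP(=O)(O)O)O2)cc1C(F)(F)F`: 0.169 ug/mL
Compound 3 `O=c1[nH]c(=O)n([C@H]2C[C@@H]3O[PH](O)(O)OC[C@H]3O2)cc1Br`: 224 ug/mL

These three compounds were tested in a functional assay (Raji cells) for antiproliferative activity, with Homo sapiens as the target; on this read-out higher numbers stand for weaker inhibition and lower numbers for stronger inhibition. Compound 3 stands at the highest number of the three, far away from both compound 2 and compound 1, whose own numbers lie close together. Going by the values given here, only one pair in the set differs in a single place: going from compound 1 to compound 3, with bromo in place of fluoro on an aromatic carbon, the number rises by a 1400-fold higher number from compound 1 to compound 3 (3.14 log units; beyond the scatter), a very large change.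

Compound 4 `O=c1[nH]c(=O)n([C@H]2C[C@@H]3O[PH](O)(O)OC[C@H]3O2)cc1Cl` has not yet been measured. It differs from compound 3 by chloro in place of bromo on an aromatic carbon.

The step from compound 1 to compound 3 is the one that bears on this change, since it alters the same aromatic carbon of the same core, and it was large. Chloro lies between fluoro and bromo in the halogen series, so a number below that of compound 3 is expected in this assay, yet nothing in the data says how far below, so the range is wide. Compound 4 is therefore expected to give roughly 40 ug/mL in this assay. For compound 4 the expected range runs from 5 ug/mL to 250 ug/mL. The expected step is a 5.6-fold lower number from compound 3 to compound 4 (0.75 log units; beyond the scatter).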

Compound 4, concentration for 50% inhibition: 337 ug/mL
Compound 4: the middle estimate sits 8.4-fold (0.93 log units) below what was measured, and the stated range ends below it.
By their numbers in this assay, from the lowest: compounds 1 and 2 (each within the scatter of the next); then compounds 3 and 4 (each within the scatter of the next).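

In this assay, putting chloro in place of bromo on this aromatic carbon gives a 1.5-fold higher number from compound 3 to compound 4 (0.18 log units; within the scatter) and so leaves the read-out unchanged within the usual scatter, which means these two halogens cannot be told apart here. Against the fluoro compound the picture is very different, with a 2100-fold higher number from compound 1 to compound 4 (3.31 log units; beyond the scatter) as the step for chloro in place of fluoro, so among these three halogens on the shared core, fluoro alone stands apart, and chloro does not fall partway between fluoro and bromo. Nothing available here explains why this single position separates fluoro so sharply from chloro and bromo.

The compounds shown leave open whether the low number belongs to fluoro alone, or whether other small groups on this aromatic carbon, such as a hydrogen, a methyl or an amine, would also give low numbers. They also leave open where an iodo group would fall, and whether the same split among the halogens would appear on the core of compound 2, which carries a different phosphate arrangement.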